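Trimethoxyphenyl chalcone-pyrazoles: removing one methoxy group

A few compounds are considered here, and "the series" means these few. Any claim that something is new, unique, unknown or untested is made for them only; others in the source may bear on it.

Measured compounds in a functional assay on HCT-116 cells (Homo sapiens) for inhibition, read by sulforhodamine B assay, with a stated time of 48 h; a higher number here means that more compound is tolerated, a lower number that less compound is tolerated:
compound 1 `COc1cc(-c2cc(/C=C/C(=O)c3ccc(F)c(F)c3)[nH]n2)cc(OC)c1OC` gives 94200 nM
compound 2 `COc1ccc(-c2cc(/C=C/C(=O)c3ccc(N)cc3)[nH]n2)cc1OC` gives 7190 nM
compound 3 `COc1cc(C(=O)/C=C/c2cc(-c3cc(OC)c(OC)c(OC)c3)n[nH]2)cc(OC)c1OC` gives 5120 nM

Compound 3 stands at the lowest of the three numbers. Its nearest neighbour is compound 2, whose number is higher but within the scatter, so the two cannot be ordered. Compound 1 lies far above both, beyond the scatter.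

Compound 4 `COc1ccc(-c2cc(/C=C/C(=O)c3cc(OC)c(OC)c(OC)c3)[nH]n2)cc1OC` is not yet measured. It differs from compound 3 by hydrogen in place of methoxy on an aromatic carbon, on the ring attached to the shared core rather than on the ring that carries the carbonyl. Within the data shown here, no pair among the measured compounds isolates this single change, so no step for it is known. Compound 2 carries the same two-methoxy ring and gives a number close to that of compound 3, but its carbonyl-side ring differs as well, so it is not a clean guide.

For compound 4 a small step is expected, a 1.3-fold higher number from compound 3 to compound 4 (0.10 log units; within the scatter), not beyond the scatter in either direction. The estimate for compound 4 is 6500 nM, with a range from 2000 nM to 20000 nM.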

Compound 4, concentration lethal to 50% of the cells: 5180 nM
Compound 4: the middle estimate sits 1.3-fold (0.10 log units) above what was measured; low and high end bracket the measured number.
By their numbers in this assay, from the lowest: compounds 3, 4 and 2 (each within the scatter of the next); then compound 1.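

Among these compounds, compound 3 and compound 4 are the first pair to isolate this change, and they give a 1.0-fold higher number from compound 3 to compound 4 (0.01 log units; within the scatter) in this assay when hydrogen replaces methoxy on this aromatic carbon, ortho to a methoxy group and meta to a large group. The two numbers cannot be ordered, so with the ring that carries the carbonyl held constant, this methoxy group, with its 2 heavy atoms and 1 hydrogen-bond acceptor, makes no difference that can be read beyond the scatter. Nothing at hand accounts for this result.

As far as these compounds go, it remains open whether a hydroxyl group or a carboxylic acid on this carbon would also stay within the scatter. From the compounds shown here alone, it is also open whether the same step would hold with other groups on the ring that carries the carbonyl, such as the two fluorines of compound 1.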